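Quinoline amide series: ring amine variation at the two-position

The source may report more compounds than this note shows. Statements on the series, on what has been measured and on what is new or still open speak of the compounds shown alone.

Measured so far:
compound 1, `CC(C)C(=O)NC1CCN(c2ccc3cc(NC(=O)CCc4ccc(C(F)(F)F)cc4)ccc3n2)C1`, 1 nM
compound 2, `O=C(CCc1ccc(C(F)(F)F)cc1)Nc1ccc2nc(N3CCC4(CCNC4)C3)ccc2c1`, 0.5 nM

In an assay on isolated protein for displacement of a labelled ligand from melanin-concentrating hormone receptor 1 (Homo sapiens) (on this read-out higher numbers stand for weaker inhibition and lower numbers for stronger inhibition), compound 2 gives 0.5 nM, the lowest of the two numbers; its nearest neighbour is compound 1, and the step of a 2.0-fold lower number from compound 1 to compound 2 (0.30 log units; within the scatter) is within the scatter, so the two are not separated. Compound 3, `O=C(CCc1ccc(C(F)(F)F)cc1)Nc1ccc2nc(N3CCCCC3)ccc2c1`, has not been measured. It differs from compound 2 as follows: a group of 6 heavy atoms (5 carbon, 1 nitrogen; one six-membered non-aromatic ring with 1 hetero atom) in place of a group of 9 heavy atoms (7 carbon, 2 nitrogen; 2 five-membered non-aromatic rings with 1 hetero atom each), on an aromatic carbon. Among the measured compounds shown here, no measured step shares this change. For the measured compounds named here, the only step at hand, from compound 1 to compound 2, exchanged one ring amine for another on the same aromatic carbon and left the number within scatter, which shows that this position has tolerated one such exchange. Compound 3 carries a smaller group with no donor, and nothing measured here tells how far the number moves without a donor. The expectation is a step of a 10-fold higher number from compound 2 to compound 3 (1.00 log units; beyond the scatter), beyond the scatter, towards a weaker number, held with low confidence. Compound 3 is estimated at 5 nM, in the range 1 nM to 30 nM.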

Compound 3, half-maximal inhibitory concentration: 12 nM
Estimate against measurement, compound 3: 2.4-fold (0.38 log units) below, and the stated range covers the measured number.
By their numbers in this assay, from the lowest: compounds 2 and 1 (each within the scatter of the next); then compound 3.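

The earlier pair showed only that this position, the aromatic carbon next to the ring nitrogen, tolerated one exchange of ring amine within the scatter. In this assay, among the compounds shown here, piperidin-1-yl now gives the first changes beyond the scatter, with a 24-fold higher number from compound 2 to compound 3 (1.38 log units; beyond the scatter) and a 12-fold higher number from compound 1 to compound 3 (1.08 log units; beyond the scatter), so the number at this position does depend on which ring amine is attached, and compounds 1 and 2, though their groups differ, both stand apart from compound 3. The step from compound 2 changes two things at once, going from 9 heavy atoms to 6 and from 1 hydrogen-bond donor to 0, and no information is available to explain the shift in the number.

The compounds shown leave open whether the heavy-atom count or the donor matters more, since no pair here varies one without the other. Piperazin-1-yl, which keeps the six-membered ring and adds a ring nitrogen, or a piperidin-1-yl ring bearing a primary amine would bear on that question, and the effect of a carboxylic acid on the ring is equally open.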